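A few compounds are considered here, and "the series" means these few. Any claim that something is new, unique, unknown or untested is made for them only; others in the source may bear on it.

Working notes on the series.

For the measured compounds named here, compound 1 `CCCNC(=O)c1cc(Oc2ccc(NC(=O)c3nn(-c4ccccc4OC(F)(F)F)c(=O)cc3C)cc2F)ccn1` is the only member with a numerical read-out: in a functional assay on HeLa cells (Homo sapiens) for antiproliferative activity, read by MTT assay, with a stated time of 72 h (on this read-out higher numbers stand for weaker inhibition and lower numbers for stronger inhibition), compound 1 gives 3690 nM. Compound 2 `CNC(=O)c1cc(Oc2ccc(NC(=O)c3nn(-c4ccccc4)c(=O)cc3C)cc2F)ccn1` is the other measured member, and in this assay compound 2 is recorded as "not active" (no number reported), with no number attached; it differs from compound 1 in more than one place, so nothing about a single step can be read from the two together. Compound 1 thus stands alone as the reference point for this assay.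

Compound 3 `CCCNC(=O)c1cc(Oc2ccc(NC(=O)c3nn(-c4cccc(C(F)(F)F)c4)c(=O)cc3C)cc2F)ccn1` has not been measured. Against compound 1 the change is 3-(trifluoromethyl)phenyl in place of 2-(trifluoromethoxy)phenyl on an aromatic nitrogen. Going by the values given here, no measured pair in the set isolates a change on the aromatic nitrogen, so there is no step to lean on; the expectation is that the value for compound 3 stays near that of compound 1, with any movement not clearly beyond the usual scatter in either direction. The step from compound 1 to compound 3 in this assay is expected to be a 1.1-fold lower number from compound 1 to compound 3 (0.02 log units; within the scatter). For compound 3 the estimate in this assay is 3500 nM, in a range from 1200 nM to 10000 nM.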

Compound 3, half-maximal inhibitory concentration: 8000 nM
Estimate against measurement, compound 3: 2.3-fold (0.36 log units) below; the measured number falls inside the stated range.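

Working notes, continued. In this assay, for the compounds shown here, the group on the aromatic nitrogen gives the first readable single change, as 3-(trifluoromethyl)phenyl in place of 2-(trifluoromethoxy)phenyl produces a 2.2-fold higher number from compound 1 to compound 3 (0.34 log units; beyond the scatter). The read-out therefore responds to a change at this position, with the move from compound 1 to compound 3 going toward weaker inhibition, although the step is modest. No measured property in hand bears on this result.

This change alters both the group and where it sits on the phenyl ring, so the contribution of exchanging trifluoromethoxy for trifluoromethyl cannot be separated from that of the new location on the ring. Also open, as far as these compounds go, is how the propylamide series would read in this assay with 2-(trifluoromethyl)phenyl or 3-(trifluoromethoxy)phenyl on the aromatic nitrogen, or with a phenyl carrying an amine or a carboxylic acid.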